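Changing the group on the sulfonyl sulfur again

The compounds below may be only part of what the source reports. "The series", "measured", "known", "first", "only" and "open" are said of these compounds alone.

Compound 1 `N#Cc1ccc(O[C@H]2CN(S(=O)(=O)c3ccc(C(F)(F)F)cc3)C[C@@]2(O)CO)cc1F` and compound 2 `N#Cc1ccc(O[C@H]2CN(S(=O)(=O)c3ccc(Cl)cn3)C[C@@]2(O)CO)cc1F` share a core and differ only in the group on a sulfonyl sulfur. In an ADME assay on the whole organism (Rattus norvegicus, strain Sprague-Dawley), read by LC-MS, with a stated time of 30 min, at a dose of 1 mg/kg by the intravenous route (a higher number here means that the compound lasts longer, a lower number that the compound disappears faster), compound 1 gives 2 h and compound 2 gives 1.2 h, so these two values cannot be told apart. Among the measured compounds shown here, compound 2 therefore has no clear standing yet, with only one neighbour to compare it against.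

Compound 3 `N#Cc1ccc(O[C@H]2CN(S(=O)(=O)c3ccc(C(F)(F)F)nc3)C[C@@]2(O)CO)cc1F` carries 6-(trifluoromethyl)pyridin-3-yl in place of 5-chloropyridin-2-yl on a sulfonyl sulfur. Its group keeps the six-membered aromatic ring with 1 hetero atom found in compound 2, and it has a trifluoromethyl group, as compound 1 does.

For the measured compounds named here, only one measured step bears on this change: a 1.7-fold lower number from compound 1 to compound 2 (0.22 log units; within the scatter). That step exchanged groups of a similar kind without leaving the scatter, so no step beyond the scatter is expected here, and no direction can be predicted with confidence. The estimated step is a 1.3-fold higher number from compound 2 to compound 3 (0.12 log units; within the scatter). In this assay the estimate for compound 3 is 1.6 h, with an expected range from 0.9 h to 2.8 h.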

Compound 3, mean residence time in the Rattus norvegicus assay: 2.3 h
Compound 3: middle estimate off by 1.4-fold (0.16 log units), on the low side, and the stated range covers the measured number.
By their numbers in the Rattus norvegicus assay, from the lowest: compounds 2, 1 and 3 (each within the scatter of the next).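

In the Rattus norvegicus assay, the new group gives a 1.9-fold higher number from compound 2 to compound 3 (0.28 log units; within the scatter), and against the first compound it gives a 1.2-fold higher number from compound 1 to compound 3 (0.06 log units; within the scatter). With 6-(trifluoromethyl)pyridin-3-yl added, three different aromatic groups on the sulfonyl sulfur now lie within the scatter of one another in the Rattus norvegicus assay, so this position has not yet produced a step that can be told apart from ordinary repeat variation. In a physicochemical assay for lipophilicity, at pH 7.4 (a lower number here means a more polar compound, a higher number a more lipophilic compound), compound 2 gives 3.4 and compound 3 gives 4.2. The same exchange between compound 2 and compound 3 does produce a clear difference in the physicochemical assay, which shows that a change beyond the scatter in that read-out can come without one in mean residence time: the measured distribution coefficient of compound 2, 3.4, and of compound 3, 4.2, a number 0.80 log units higher (beyond the scatter)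

All three groups shown are aromatic rings, so it remains open whether a group of another kind on the sulfonyl sulfur, such as a simple alkyl chain or a ring carrying an amine or a carboxylic acid, would move the number in the Rattus norvegicus assay beyond the scatter. A single pair also cannot show whether a larger gap in the physicochemical assay would be matched by a clear step in the Rattus norvegicus assay.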